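The compounds below may be only part of what the source reports. "The series", "measured", "known", "first", "only" and "open" are said of these compounds alone.

Measured in a functional assay on L1210 cells (Mus musculus) for inhibition; on this read-out lower numbers stand for stronger inhibition and higher numbers for weaker inhibition:

Compound 1, `O=c1ccn(COCCO)c(=O)[nH]1`: > 1000 ug/mL
Compound 2, `Nc1nc(=O)ccn1COCCO`: > 500 ug/mL
Compound 3, `OCCOCn1cnc2c(O)ncnc21`: > 1000 ug/mL

None of these three readings is a real number; each is a limit of this assay. For compound 1 the reading > 1000 ug/mL is such a limit. For compound 2 the reading > 500 ug/mL is likewise a limit. Compound 3 stands only at a limit as well, > 1000 ug/mL, so its true position is not known. Two of the three readings sit at the limit of > 1000 ug/mL in this assay, at which 2 of the 3 values shown sit. The remaining one sits at the limit of > 500 ug/mL in this assay, at which 1 of the 3 values shown sits. Within the data shown here, with nothing but limits, no step between measured compounds can be drawn, and no structural change has yet been linked to a shift in this assay.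

Compound 4, `CN(C)c1ncnc2c1ncn2COCCO`, has not been measured. It differs from compound 3 in one place: dimethylamino in place of hydroxy on an aromatic carbon. With every known compound sitting at a limit, the step from compound 3 to compound 4 is expected to be an at least 1.2-fold lower number from compound 3 to compound 4 (0.09 log units; that floor lies within the scatter), that is, nothing beyond the scatter. Compound 4 is therefore expected near 800 ug/mL, within 200 ug/mL to 2000 ug/mL, and most likely this assay will again report only a limit for it.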

Compound 4, concentration for 50% inhibition: > 500 ug/mL
Compound 4 ended at the assay's limit; the forecaster's own chance of this, stated with the estimate: 80%; the middle value lies beyond the limit too.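

Among these compounds, compound 3 and compound 4 both give only a limit in this assay, and no step between them can be read. The compounds shown leave open whether dimethylamino in place of hydroxy on an aromatic carbon shifts inhibition at all, and what real value any of the four compounds has.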